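The source may report more compounds than this note shows. Statements on the series, on what has been measured and on what is new or still open speak of the compounds shown alone.

Measured so far:
- Compound 1 `COc1cc(C(=O)O)ccc1OCCCCOc1ccc(C(=O)CC(C)C)c(O)c1C` gives 14.6 mL/min/kg
- Compound 2 `Cc1c(OCCCCOc2ccc(C(=O)O)cc2)ccc(C(=O)CC(C)C)c1O` gives 21.1 mL/min/kg

Going by the values given here, in an ADME assay on the whole organism for pharmacokinetics, with Rattus norvegicus as the target, at a dose of 2 mg/kg by the intravenous route (on this read-out lower numbers stand for slow clearance and higher numbers for fast clearance), compound 2 stands at 21.1 mL/min/kg, and with only two compounds measured, it lies within the usual scatter of compound 1. The next compound to be measured is compound 3 `Cc1c(OCCCCOc2ccc(F)c(C(=O)O)c2)ccc(C(=O)CC(C)C)c1O`. It differs from compound 2 by 3-carboxy-4-fluorophenyl in place of 4-carboxyphenyl on an oxygen on a saturated carbon. In words, a 3-carboxy-4-fluorophenyl sits in place of the 4-carboxyphenyl on an oxygen on a saturated carbon.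

Among the compounds with values here, only one measured step offers any guide: a 1.4-fold higher number from compound 1 to compound 2 (0.16 log units; within the scatter). That step also alters the 4-carboxyphenyl group, but it swaps methoxy for hydrogen, so it is a different change. Within the data shown here, no measured compound carries the 3-carboxy-4-fluorophenyl group, so the data point in no particular direction. Among the measured compounds shown here, since the one measured step of a 1.4-fold higher number from compound 1 to compound 2 (0.16 log units; within the scatter) stays small, no shift beyond the scatter is expected. The estimate therefore means a 1.1-fold lower number from compound 2 to compound 3 (0.02 log units; within the scatter), which is expected to be no real change. For compound 3 the expected value is 20 mL/min/kg, with an estimated range of 10 mL/min/kg to 40 mL/min/kg.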

Compound 3, clearance: 38.8 mL/min/kg
Compound 3: middle estimate off by 1.9-fold (0.29 log units), on the low side; the range from low to high includes it.
By their numbers in this assay, from the lowest: compounds 1, 2 and 3 (each within the scatter of the next, the first and the last beyond it).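

In this assay, putting 3-carboxy-4-fluorophenyl in place of 4-carboxyphenyl on an oxygen on a saturated carbon gives a 1.8-fold higher number from compound 2 to compound 3 (0.26 log units; within the scatter), so the group at this place can be rebuilt in this way without a step beyond the usual spread of repeat measurements. This single step bundles two edits, since a fluorine enters and the carboxy group also carries a different number in the group's name, and the result cannot assign any part of the step to either edit. No separate measurement is available to explain the clearance of compound 2 or compound 3.

The compounds shown leave open how a 3-carboxyphenyl group, which has the same numbering as in compound 3 but no fluorine, would read at this place, and such a compound would divide the step into its two edits. As far as these compounds go, it also remains open whether a chlorine in the place of that fluorine, or a longer chain between the two oxygens, would give a step that clears the scatter.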